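Swapping the pentan-3-yl for 4-nitrophenyl on the ester carbon

A few compounds are considered here, and "the series" means these few. Any claim that something is new, unique, unknown or untested is made for them only; others in the source may bear on it.

The two measured compounds share a core: compound 1 `C=C(C(=O)c1ccc(OC)cc1)C(OC(C)=O)c1ccc([N+](=O)[O-])cc1` and compound 2 `C=C(C(=O)c1ccc(OC)cc1)C(OC(=O)c1ccccc1)C(CC)CC`. In a functional assay on NB-4 cells (Homo sapiens) for inhibition, read by XTT assay, with a stated time of 48 h (a lower number here means a stronger inhibitor, a higher number a weaker inhibitor), compound 1 gives 10300 nM. In this assay compound 2 gives 13000 nM, and the two numbers lie within the usual scatter of each other. Compound 3 `C=C(C(=O)c1ccc(OC)cc1)C(OC(=O)c1ccccc1)c1ccc([N+](=O)[O-])cc1` differs from compound 2 by 4-nitrophenyl in place of pentan-3-yl on a saturated chain carbon bound to a double-bonded chain carbon and an oxygen next to a carbonyl group. Going by the values given here, with no measured step of this kind available, the change from compound 2 to compound 3 is expected to bring at most a small shift in this assay, as a 1.2-fold lower number from compound 2 to compound 3 (0.07 log units; within the scatter). Compound 3 is therefore estimated at 11000 nM, within 4000 nM to 30000 nM.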

Compound 3, half-maximal inhibitory concentration: 13200 nM
For compound 3 the middle estimate is 1.2-fold (0.08 log units) below the measured one, within the range that was stated.
By their numbers in this assay, from the lowest: compounds 1, 2 and 3 (each within the scatter of the next).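

In this assay, 4-nitrophenyl in place of pentan-3-yl on the saturated chain carbon gives a 1.0-fold higher number from compound 2 to compound 3 (0.01 log units; within the scatter), so this exchange of a branched chain for an aromatic ring leaves the number within the scatter. Phenyl in place of methyl on the carbonyl carbon gives a 1.3-fold higher number from compound 1 to compound 3 (0.11 log units; within the scatter), also within the scatter, so neither place has yet shown a step beyond it. Nothing available bears on why these numbers stay together. Going by these compounds, whether an amine or a carboxylic acid on the saturated chain carbon, or a longer chain on the carbonyl carbon, would shift the number remains open.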